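The source may report more compounds than this note shows. Statements on the series, on what has been measured and on what is new or still open speak of the compounds shown alone.

For the measured compounds named here, in a physicochemical assay for lipophilicity, at pH 7.4 (a lower number here means a more polar compound, a higher number a more lipophilic compound), compound 1 (`COc1cccc(C(=O)NCc2c(C)cc(C)[nH]c2=O)c1Cl`) gives 1.2, the lower of the two numbers so far and beyond the scatter from compound 2 (`Cc1cc(C)c(CNC(=O)c2cccc(OC(C)C)c2Cl)c(=O)[nH]1`), which gives 2. Compound 3 (`COc1cccc(C(=O)NCc2c(C)cc(C)[nH]c2=O)c1OC`) has methoxy in place of chloro on an aromatic carbon, ortho to a large group and ortho to a methoxy group: methoxy in place of chloro on an aromatic carbon. Going by the values given here, the only measured step, a number 0.80 log units higher from compound 1 to compound 2 (beyond the scatter), is modest and lies at another place, so it offers a rough size but no direction. A modest fall in this assay is nevertheless expected, with an estimated step of a number 0.40 log units lower from compound 1 to compound 3 (beyond the scatter). Compound 3 is expected at 0.8, with an estimated range of 0.4 to 1.2.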

Compound 3, distribution coefficient: 1.7
Compound 3: the middle estimate sits 0.90 log units below what was measured; the whole stated range lies below it.
By their numbers in this assay, from the lowest: compound 1; then compounds 3 and 2 (each within the scatter of the next).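

For the compounds shown here, compound 3 gives the first reading at this position, on an aromatic carbon ortho to a large group and ortho to a methoxy group. In this assay, methoxy in place of chloro gives a number 0.50 log units higher from compound 1 to compound 3 (beyond the scatter), so the position is not silent in this assay, and the number goes up even though the entering methoxy counts one hydrogen-bond acceptor and the leaving chloro none. No measurement at hand accounts for this direction.

The compounds shown leave open whether an amine or a longer chain at this place would move the number the same way. They also leave open whether the step holds in the core of compound 2.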